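Moving the chlorine on the aryl group of compound 3

This account rests on a few compounds, and the source may have more. Where it says the series, first, only, none or still open, it means among the compounds named here.

Measured compounds:
compound 1 `O=C(Nn1c(-c2cccc([N+](=O)[O-])c2)nc2c(-c3ccc(Cl)cc3)n[nH]c2c1=O)c1cccnc1` — 16.3%
compound 2 `CCCc1n[nH]c2c(=O)n(NC(=O)c3ccccc3)c(-c3cccc([N+](=O)[O-])c3)nc12` — 22.9%
compound 3 `O=C(Nn1c(-c2cccc([N+](=O)[O-])c2)nc2c(-c3cccc(Cl)c3)n[nH]c2c1=O)c1ccccc1` — 78.2%

In a functional assay on SK-MEL-2 cells (Homo sapiens) for cytotoxicity, read by sulforhodamine B assay, with a stated time of 2 days, tested at 100 uM (on this read-out lower numbers stand for less inhibition and higher numbers for more inhibition at the one concentration tested (going by the name of the read-out)), compound 3 gives 78.2%, the highest of the three numbers. Its nearest neighbour is compound 2 with 22.9%, and compound 1 stands furthest away with 16.3%. Going by the values given here, the only one-place step among the measured compounds is a number 55.3 percentage points higher from compound 2 to compound 3 (beyond the scatter), a large rise from propyl to 3-chlorophenyl.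

Compound 4 `O=C(Nn1c(-c2cccc([N+](=O)[O-])c2)nc2c(-c3ccc(Cl)cc3)n[nH]c2c1=O)c1ccccc1` differs from compound 3 by 4-chlorophenyl in place of 3-chlorophenyl on an aromatic carbon. Among the compounds with values here, no measured step covers this exchange. Compound 1 also carries 4-chlorophenyl, yet it differs from compound 3 in a second place as well, so its low value cannot be laid to the chlorophenyl alone. Compound 1 and compound 3 together only show that a 4-chlorophenyl compound of this core can sit far lower than compound 3.

With so little to rest on, a moderate fall is expected for compound 4, estimated as a number 30.2 percentage points lower from compound 3 to compound 4 (beyond the scatter), giving 48% with a wide range from 15% to 82%.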

Compound 4, a percentage reported as inhibition, at one concentration (the size of the read-out at that concentration, not a potency): 89%
The estimate for compound 4 lay 41 percentage points below the measured number, and the stated range ends below it.
By their numbers in this assay, from the lowest: compounds 1 and 2 (each within the scatter of the next); then compound 3; then compound 4.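

In this assay, 4-chlorophenyl in place of 3-chlorophenyl on this aromatic carbon gives a number 10.8 percentage points higher from compound 3 to compound 4 (beyond the scatter) and is a modest step, so moving the chlorine to this ring position does not lower the number. Replacing propyl here with the same group gives a number 66.1 percentage points higher from compound 2 to compound 4 (beyond the scatter) as a large step, so both chlorophenyl groups stand far above propyl. Phenyl in place of pyridin-3-yl on a carbonyl carbon gives a number 72.7 percentage points higher from compound 1 to compound 4 (beyond the scatter) with the 4-chlorophenyl group unchanged, so the low number seen with pyridin-3-yl belongs to that exchange and not to the 4-chlorophenyl group.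

Nothing shown accounts for any of these steps. The compounds shown leave open how 2-chlorophenyl, 4-methoxyphenyl or a longer alkyl chain would read at this position.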